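A few compounds are considered here, and "the series" means these few. Any claim that something is new, unique, unknown or untested is made for them only; others in the source may bear on it.

Compound 1 `COc1cccc(/C=C2\CCC/C(=C\c3ccccc3Br)C2=O)c1OC`: 12100 nM
Compound 2 `COc1cccc(/C=C2\CCC/C(=C\c3ccc(Br)cc3)C2=O)c1OC`: 11100 nM
Compound 3 `COc1ccccc1/C=C1\CCC/C(=C\c2cccc(OC)c2OC)C1=O`: > 20000 nM (a limit, not a number)

All three readings come from a functional assay on SW-620 cells (Homo sapiens) for cytotoxicity, read by MTT assay, with a stated time of 72 h; on this read-out lower numbers stand for stronger inhibition and higher numbers for weaker inhibition. Compound 3 gives only a limit, > 20000 nM.

Compound 4 `COc1cccc(/C=C2\CCC/C(=C\c3cccc(OC)c3OC)C2=O)c1` has the same atoms as compound 3, joined differently: 3-methoxyphenyl in place of 2-methoxyphenyl on a double-bonded chain carbon bound to a double-bonded ring carbon. The change is 3-methoxyphenyl in place of 2-methoxyphenyl on a double-bonded chain carbon bound to a double-bonded ring carbon.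

The closest measured precedent is the exchange of 2-bromophenyl for 4-bromophenyl in that same place, which gives a 1.1-fold lower number from compound 1 to compound 2 (0.04 log units; within the scatter). The other two steps, an at least 1.6-fold higher number from compound 1 to compound 3 (0.21 log units; that floor lies within the scatter) and an at least 1.8-fold higher number from compound 2 to compound 3 (0.25 log units; that floor lies within the scatter), provide only floors and fix no size.

On this precedent, no step beyond the scatter is expected in this assay. The expected step is an at least 1.2-fold lower number from compound 3 to compound 4 (0.09 log units; that floor lies within the scatter). Another limit reading would not be surprising.

The estimate for compound 4 is 16000 nM, with an expected range of 8000 nM to 30000 nM.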

Compound 4, half-maximal inhibitory concentration: 7000 nM
The estimate for compound 4 lay 2.3-fold (0.36 log units) above the measured number; the whole stated range lies above it.
By their numbers in this assay, from the lowest: compounds 4, 2 and 1 (each within the scatter of the next). At a limit, above all of these: compound 3.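

In this assay, among the compounds shown here, 3-methoxyphenyl in place of 2-methoxyphenyl on a double-bonded chain carbon bound to a double-bonded ring carbon gives the first step beyond the scatter (an at least 2.8-fold lower number from compound 3 to compound 4 (0.45 log units; beyond the scatter)), so an isomer exchange at this place can register, which the bromophenyl exchange (a 1.1-fold lower number from compound 1 to compound 2 (0.04 log units; within the scatter)) did not show. That size is only a floor, because compound 3 gives a limit and not a number: the limit of > 20000 nM in this assay, at which 1 of the 4 values shown sits. With 3-methoxyphenyl in that place, the steps from the two bromophenyl compounds stay within the scatter (a 1.6-fold lower number from compound 2 to compound 4 (0.20 log units; within the scatter) and a 1.7-fold lower number from compound 1 to compound 4 (0.24 log units; within the scatter)), so the bromophenyl compounds and compound 4 do not separate.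

Open, as far as these compounds go, is how a 4-methoxyphenyl group, an amine or a carboxylic acid would read on that same chain carbon. From the compounds shown here alone, the full size of the step from the 2-methoxyphenyl compound also remains open.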